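The source may report more compounds than this note shows. Statements on the series, on what has been measured and on what is new or still open speak of the compounds shown alone.

Three compounds share one core and differ in the chain attached to the amine nitrogen, and the question is how much that chain matters for binding. Compound 1 `COCCNc1nc(C)nc2c1nnn2-c1c(C)cc(C)cc1C` carries the smallest chain; in an in vitro assay on 293-EBNA cells for binding affinity to corticotropin-releasing factor receptor 1 (Homo sapiens) (on this read-out higher numbers stand for weaker inhibition and lower numbers for stronger inhibition), compound 1 gives 1200 nM. Compound 2 `CCC(COC)Nc1nc(C)nc2c1nnn2-c1c(C)cc(C)cc1C` differs from compound 1 in one place, (ethyl in place of hydrogen on a saturated chain carbon bound to a nitrogen on an aromatic ring and a saturated chain carbon). In this assay compound 2 gives 59.4 nM. The consequence of that change is large: a 20-fold lower number from compound 1 to compound 2 (1.31 log units; beyond the scatter). Compound 3 `CCCCC(CC)Nc1nc(C)nc2c1nnn2-c1ccc(C(C)C)cc1Br` has a different aromatic ring on the core and a longer chain; in this assay compound 3 gives 3.1 nM, the lowest number among the three. The difference between the core of compound 3 and the core of compound 1 is not broken down here.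

Compound 4 `CCCCC(CCCC)Nc1nc(C)nc2c1nnn2-c1ccc(C(C)C)cc1Br` has not yet been measured. It differs from compound 3 by ethyl in place of hydrogen on a saturated chain carbon, three bonds along the chain from a nitrogen on an aromatic ring. Among the compounds with values here, this is the same kind of change as the one from compound 1 to compound 2, but the place is not the same: there the ethyl entered on a saturated chain carbon bound to a nitrogen on an aromatic ring and a saturated chain carbon, whereas here it enters three bonds along the chain from the nitrogen. A step of the size seen from compound 1 to compound 2 is therefore not expected for compound 3 to compound 4, and compound 3 already sits at a low number, so the expected step is small, a 1.1-fold higher number from compound 3 to compound 4 (0.05 log units; within the scatter). For compound 4 in this assay the estimated value is 3.5 nM, with a range from 1.2 nM to 12 nM.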

Compound 4, inhibition constant: 4.5 nM
Beside the measured number, compound 4's estimate is 1.3-fold (0.11 log units) below it, within the range that was stated.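

In this assay the new step reads a 1.5-fold higher number from compound 3 to compound 4 (0.16 log units; within the scatter), so the two chains on this core cannot be told apart, and the added ethyl neither helps nor harms by any measurable amount. Set beside the earlier step, the same kind of change clearly does not keep its size from one core to the other: the same change on two cores in this assay, a 20-fold lower number (1.31 log units; beyond the scatter) from compound 1 to compound 2 and a 1.5-fold higher number (0.16 log units; within the scatter) from compound 3 to compound 4, 29-fold (1.47 log units) apart, beyond the scatter of two such steps. Within the data shown here, this shows that the large effect seen on the core of compound 1 cannot simply be assumed on the core of compound 3, but it does not show why, since the two pairs differ in their aromatic ring, in the chain that receives the ethyl and in the place where the ethyl enters, and each core offers only a single pair.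

Still open, from the compounds shown here alone, is how the ethyl would behave if it entered at the same place on both cores, which would separate the effect of the core from the effect of the place. Also open, going by these compounds, is whether a chain longer than 1-butylpentyl, or one carrying an amine or a carboxylic acid, would leave the number where it stands on the core of compound 3 or move it beyond the usual scatter.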